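Swapping the Aryl Group on a Shared Core

The compounds below may be only part of what the source reports. "The series", "measured", "known", "first", "only" and "open" are said of these compounds alone.

Measured so far:
- Compound 1, `C=CCn1c(=O)/c(=C\c2cc(F)ccc2C)[nH]c(=O)/c1=C\c1ccccc1OC`: 7300 nM
- Compound 2, `C=CCn1c(=O)/c(=C\c2cccc(Br)c2)[nH]c(=O)/c1=C\c1ccccc1OC`: "not active" (no number reported)
- Compound 3, `C=CCn1c(=O)/c(=C\c2ccccc2Cl)[nH]c(=O)/c1=C\c1ccccc1OC`: 9200 nM

All three share one core and differ only in the aromatic ring that sits on a double-bonded chain carbon bound to an aromatic carbon. In a functional assay on NCI-H1975 cells (Homo sapiens) for cytotoxicity, read by CCK-8 assay, with a stated time of 72 h (a lower number here means a stronger inhibitor, a higher number a weaker inhibitor), compound 3 gives 9200 nM, the higher of the two numbers reported; its nearest neighbour is compound 1, and the step of a 1.3-fold higher number from compound 1 to compound 3 (0.10 log units; within the scatter) lies within the scatter, so the two cannot be told apart. Among the measured compounds shown here, compound 2 gives "not active" (no number reported), and no step to it is counted.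

Compound 4 is `C=CCn1c(=O)/c(=C\c2cc(Br)ccc2F)[nH]c(=O)/c1=C\c1ccccc1OC`. Its change from compound 3 is 5-bromo-2-fluorophenyl in place of 2-chlorophenyl on a double-bonded chain carbon bound to an aromatic carbon. For the measured compounds named here, the only measured step that bears on this kind of change, from compound 1 to compound 3, was small and within the scatter. Going by the values given here, the one compound carrying a bromine, compound 2, returned no number at all, which leaves open that a bromine-bearing ring may also fall outside the measurable range.

On this thin evidence, no change beyond the scatter is expected: a 1.0-fold lower number from compound 3 to compound 4 (0.01 log units; within the scatter). Compound 4 is therefore estimated at 9000 nM, with a likely range from 3000 nM to 30000 nM, and a real chance that only a limit is reported.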

Compound 4, half-maximal inhibitory concentration: "not active" (no number reported)
Nothing numeric was reported for compound 4; the estimate stays without a comparison.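

In this assay, among the compounds shown here, compound 4 gives "not active" (no number reported), so no step from compound 3 to compound 4 can be read. Nothing measured here offers an explanation for this result. The compounds shown leave open whether the bromine carried by both compound 2 and compound 4 is what separates them from compound 1 and compound 3, which give numbers.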